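Replacing the Cyclohexyl Group of Compound 1

This account rests on a few compounds, and the source may have more. Where it says the series, first, only, none or still open, it means among the compounds named here.

Compound 1 `COc1ncccc1C(=O)NCCC1CCN(S(=O)(=O)NC(=O)NC2CCCCC2)CC1` was tested in a functional assay on the whole organism (blood) with Rattus norvegicus as the target, with stated times of 24 h and 1 h, at a dose of 5 mg/kg by the intraperitoneal route (on this read-out higher numbers stand for a stronger effect at the one dose given and lower numbers for a weaker effect), where compound 1 gives 33%. Compound 3 `O=C(NC1CCCCC1)NS(=O)(=O)N1CCC(CCNC(=O)c2cccc3c2OCCO3)CC1` gives 34%, a result that is a number 1 percentage points higher from compound 1 to compound 3 (within the scatter). Compound 2 `COc1ccc2nccc(C(=O)NCCC3CCN(S(=O)(=O)NC(=O)NC4CCCCC4)CC3)c2c1` gives 15%, a result that is a number 18 percentage points lower from compound 1 to compound 2 (beyond the scatter). Compound 1 therefore stands second highest of the three, close to compound 3 and clearly above compound 2. Compound 4 `COc1ncccc1C(=O)NCCC1CCN(S(=O)(=O)NC(=O)NCC2CCCCO2)CC1` differs from compound 1 in one place: (oxan-2-yl)methyl in place of cyclohexyl on an amide-type nitrogen. Every measured step changed the group on the carbonyl carbon, not this amide-type nitrogen, so none of them bears directly on the new change, and the outlook rests on the shared core alone. The expected step is a number 3 percentage points lower from compound 1 to compound 4 (within the scatter), with nothing beyond the scatter anticipated. Compound 4 is estimated at 30%, within a range from 15% to 45%.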

Compound 4, a percentage reported as activity, at one dose (the size of the read-out at that dose, not a potency): 12%
The estimate for compound 4 lay 18 percentage points above the measured number; the measured number lies below the stated range.
By their numbers in this assay, from the lowest: compounds 4 and 2 (each within the scatter of the next); then compounds 1 and 3 (each within the scatter of the next).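

The first change shown on this amide-type nitrogen gives, in this assay, a number 21 percentage points lower from compound 1 to compound 4 (beyond the scatter). The group here therefore matters to the read-out, even though the core of compound 1 and the group on the carbonyl carbon stay the same. The change also brings in two things at once: a ring oxygen and a carbon link between the ring and the nitrogen.

Which of these goes with the lower number stays open, and a cyclohexylmethyl group on the same nitrogen would separate them. No measurement bearing on the reason for this step is at hand.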